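The source may report more compounds than this note shows. Statements on the series, on what has been measured and on what is new or still open speak of the compounds shown alone.

Measured compounds:
Compound 1 `C/N=C(\S)OC[C@H]1OC(n2cnc3c(NC4CCOC4)ncnc32)[C@H](O)[C@@H]1O`: 45 nM in an assay on DDT1 cells (Cricetulus griseus) for binding affinity to adenosine receptor A1 (Homo sapiens), read by radioligand binding; a lower number here means a stronger inhibitor, a higher number a weaker inhibitor
Compound 2 `CCCC/N=C(\S)OC[C@H]1OC(n2cnc3c(NC4CCOC4)ncnc32)[C@H](O)[C@@H]1O`: 157 nM
Compound 3 `O[C@@H]1[C@@H](CO/C(S)=N/C2CCC2)OC(n2cnc3c(NC4CCOC4)ncnc32)[C@@H]1O`: 148 nM

Compound 3 holds the second highest of the three numbers; its neighbour is compound 2, with a 1.1-fold lower number from compound 2 to compound 3 (0.03 log units; within the scatter), and its furthest partner is compound 1, with a 3.3-fold higher number from compound 1 to compound 3 (0.52 log units; beyond the scatter). Compound 4 `C=CCNC(=O)OC[C@H]1OC(n2cnc3c(NC4CCOC4)ncnc32)[C@H](O)[C@@H]1O` differs from compound 3 by a group of 6 heavy atoms (4 carbon, 1 nitrogen, 1 oxygen; no ring) in place of a group of 7 heavy atoms (5 carbon, 1 nitrogen, 1 sulfur; one four-membered non-aromatic ring of carbon only), on an oxygen on a saturated carbon. Of the measured steps, only those at the double-bonded nitrogen bear on this change: a 3.3-fold higher number from compound 1 to compound 3 (0.52 log units; beyond the scatter) and a 1.1-fold lower number from compound 2 to compound 3 (0.03 log units; within the scatter). Within the data shown here, no measured pair tests the exchange of sulfur for oxygen. Since the chain-for-ring swap in a 1.1-fold lower number from compound 2 to compound 3 (0.03 log units; within the scatter) was within the scatter, a step of at most modest size in this assay is expected, a 1.3-fold lower number from compound 3 to compound 4 (0.13 log units; within the scatter). Compound 4 is therefore estimated at 110 nM, between 30 nM and 400 nM.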

Compound 4, inhibition constant: 524 nM
The estimate for compound 4 lay 4.8-fold (0.68 log units) below the measured number; the measured number lies above the stated range.
By their numbers in this assay, from the lowest: compound 1; then compounds 3 and 2 (each within the scatter of the next); then compound 4.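

In this assay, among these compounds, allylcarbamoyl on this oxygen on a saturated carbon gives the highest number so far, with steps from each earlier compound beyond the scatter (a 3.5-fold higher number from compound 3 to compound 4 (0.55 log units; beyond the scatter)) and (a 3.3-fold higher number from compound 2 to compound 4 (0.52 log units; beyond the scatter)) and (a 12-fold higher number from compound 1 to compound 4 (1.07 log units; beyond the scatter)). This exchange brings in oxygen for sulfur and a new chain together, so the steps do not separate the two. Nothing shown gives a reason for the rise. From the compounds shown here alone, it remains open how an allyl on the double-bonded nitrogen of the sulfur-bearing group would read, and how methylcarbamoyl would read in place of allylcarbamoyl.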